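The compounds below may be only part of what the source reports. "The series", "measured", "known", "first", "only" and "open" are said of these compounds alone.

Working notes on the series

Compound 1 `Cc1ccc(OCC(=O)N(Cc2cccs2)c2cnn(C)c2)cc1` sits at the upper end of the numbers recorded so far: in an assay on HEK293 cells for agonist activity at transient receptor potential cation channel subfamily M member 8 (Homo sapiens), read by fluorescence and calcium flux, with a stated time of 15 min (a lower number here means that less compound is needed, a higher number that more compound is needed for the effect), compound 1 gives 63000 nM. Compound 2 `CCN(Cc1cccs1)C(=O)COc1ccc(C(C)C)cc1` in this assay gives 397 nM, a gap from compound 1 far beyond the scatter, and compound 3 `CCN(Cc1cccs1)C(=O)COc1ccc(C(=O)O)cc1` is reported as "not active" (no number reported) in this assay, with no number attached. Compound 4 `Cc1ccc(OCC(=O)N(Cc2cccs2)C2CCCCC2)cc1` has not yet been measured in this assay. It differs from compound 1 in one place: cyclohexyl in place of 1-methyl-1H-pyrazol-4-yl on an amide-type nitrogen. Within the data shown here, no measured pair in the set shares exactly this change, so the expected direction rests only on the spread of the numbers seen so far. Given that compound 1 stands at 63000 nM while compound 2 reaches 397 nM, the expected step from compound 1 to compound 4 in this assay is a 16-fold lower number from compound 1 to compound 4 (1.20 log units; beyond the scatter), toward a lower number, and clearly beyond the scatter. Among the measured compounds shown here, for compound 4 in this assay the estimate is 4000 nM, with a range from 800 nM to 20000 nM; the range is wide because the only anchor is compound 1 at 63000 nM.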

Compound 4, half-maximal effective concentration: 40000 nM
Estimate against measurement, compound 4: 10-fold (1.00 log units) below; the measured number lies above the stated range.
By their numbers in this assay, from the lowest: compound 2; then compounds 4 and 1 (each within the scatter of the next).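

On the amide-type nitrogen whose other neighbours are the carbonyl carbon and a saturated chain carbon, cyclohexyl in place of 1-methyl-1H-pyrazol-4-yl gives, in this assay, a 1.6-fold lower number from compound 1 to compound 4 (0.20 log units; within the scatter). For this one pair, then, a five-membered aromatic ring with 2 hetero atoms and a six-membered non-aromatic ring of carbon only are not told apart, although hydrogen-bond acceptors in the group go from 2 to 0. No measured evidence is at hand that bears on this result.

Going by these compounds, whether a longer chain such as n-hexyl or an amine such as piperidin-4-yl on this nitrogen would read any differently remains open. Compound 2 and compound 3 carry ethyl there but also differ from compound 4 elsewhere, so the role of that nitrogen substituent alone remains unresolved.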